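A few compounds are considered here, and "the series" means these few. Any claim that something is new, unique, unknown or untested is made for them only; others in the source may bear on it.

For the measured compounds named here, in a functional assay on MCF7 cells (Homo sapiens) for inhibition, read by sulforhodamine B assay, with a stated time of 48 h (on this read-out lower numbers stand for stronger inhibition of growth and higher numbers for weaker inhibition of growth), compound 2 `CC1=CC[C@H](C(C)(C)NC(=S)N/N=C/c2ccccc2Cl)CC1` gives 98300 nM, the highest of the two numbers so far. The nearest is compound 1 `COc1ccc(/C=N/NC(=S)NC(C)(C)[C@H]2CC=C(C)CC2)cc1`, which in this assay gives 37700 nM. Going by the values given here, the one measured step, a 2.6-fold higher number from compound 1 to compound 2 (0.42 log units; beyond the scatter), concerns 2-chlorophenyl in place of 4-methoxyphenyl and so touches the group now rearranged only in part. Compound 3 `CC1=CC[C@H](C(C)(C)NC(=S)N/N=C/c2ccc(Cl)cc2)CC1` differs from compound 2 by 4-chlorophenyl in place of 2-chlorophenyl on a carbon with a double bond to nitrogen. Among the compounds with values here, no measured step bears directly on this rearrangement. A modest move toward the number of compound 1 is expected, with a step of a 1.6-fold lower number from compound 2 to compound 3 (0.21 log units; within the scatter). For compound 3 the expected value is 60000 nM, with a range from 20000 nM to 180000 nM.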

Compound 3, concentration for total growth inhibition: > 100000 nM
Compound 3 gave a limit, no number (the forecaster's own chance of this, stated with the estimate: 15%); at least 1.6-fold (0.22 log units) between middle value and limit.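

In this assay, compound 3 gives > 100000 nM, which is a limit and not a number. The change from 2-chlorophenyl to 4-chlorophenyl gives an at least 1.0-fold higher number from compound 2 to compound 3 (0.00 log units; that floor lies within the scatter), so no order between these two compounds can be stated. Chloro in place of methoxy on an aromatic carbon gives an at least 2.6-fold higher number from compound 1 to compound 3 (0.42 log units; beyond the scatter), so with the earlier step, 4-methoxyphenyl now stands apart from both chlorophenyl groups, with compound 1 giving the lower number. As far as these compounds go, how far compound 3 lies from compound 2 stays open. Also open, from the compounds shown here alone, is whether an amine or a hydroxyl in place of methoxy would bring the number below that of compound 1.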